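The compounds below may be only part of what the source reports. "The series", "measured", "known", "first", "only" and "open" are said of these compounds alone.

Compound 1 `CC(C)(C)OC(=O)CC[C@H](NC(=O)c1cc(Cl)ccc1OCCNC(=O)OC(C)(C)C)C(=O)Nc1ccc([N+](=O)[O-])cc1Cl` carries a tert-butoxycarbonyl group on an amine nitrogen. In a functional assay on MCF7 cells (Homo sapiens) for inhibition, read by MTT assay, with a stated time of 72 h (on this read-out higher numbers stand for weaker inhibition and lower numbers for stronger inhibition), compound 1 reaches only a limit of the measurement, > 10000 nM. Compound 2 `CC(C)(C)OC(=O)CC[C@H](NC(=O)c1cc(Cl)ccc1OCCN)C(=O)Nc1ccc([N+](=O)[O-])cc1Cl` differs from it by hydrogen in place of tert-butoxycarbonyl on an amine nitrogen. In this assay compound 2 gives 3080 nM, so this change produced an at least 3.2-fold lower number from compound 1 to compound 2 (0.51 log units; beyond the scatter). Compound 3 `CC(C)[C@H](NC(=O)c1cc(Cl)ccc1OCCNC(=O)OC(C)(C)C)C(=O)Nc1ccc(C(F)(F)F)cc1Cl` rests on another core; how its core differs from that of compound 1 is not broken down here. In this assay compound 3 also gives only a limit, > 10000 nM, which means two of the three values sit at the limit of > 10000 nM in this assay, at which 2 of the 3 values shown sit. Compound 4 `CC(C)[C@H](NC(=O)c1cc(Cl)ccc1OCCN)C(=O)Nc1ccc(C(F)(F)F)cc1Cl` differs from compound 3 by hydrogen in place of tert-butoxycarbonyl on an amine nitrogen, the same change as that from compound 1 to compound 2. Because the earlier change gave an at least 3.2-fold lower number from compound 1 to compound 2 (0.51 log units; beyond the scatter), a comparable step is expected here: an at least 2.0-fold lower number from compound 3 to compound 4 (0.30 log units; that floor lies within the scatter). Compound 4 is therefore estimated at 5000 nM.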

Compound 4, half-maximal inhibitory concentration: > 10000 nM
Compound 4 gave a limit, no number; the forecaster's own chance of this, stated with the estimate: 35%; middle value at least 2.0-fold (0.30 log units) away from the limit.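

For the compounds shown here, compound 3 and compound 4 both stop at a limit, so no step between them can be read: the limit of > 10000 nM in this assay, at which 3 of the 4 values shown sit. The compounds shown leave open whether hydrogen in place of tert-butoxycarbonyl changes the number on the core of compound 3.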